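Benzoyl in Place of Hydroxy on the Thiourea Aryl Ring

The source may hold more compounds than are shown below. What is called first, only, known or untested is meant among the compounds shown, and "the series" means these compounds.

Measured so far:
compound 1, `Oc1ccc(NC(=S)Nc2ccc3[nH]ccc3c2)cc1`: 41.5%
compound 2, `OCc1ccc(NC(=S)Nc2ccc3[nH]ccc3c2)cc1`: 88.3%
compound 3, `CC(=O)c1ccc(NC(=S)Nc2ccc3[nH]ccc3c2)cc1`: 66.3%

In an ADME assay on isolated protein for inhibition of peroxidase (Raphanus sativus), read by fluorescence and Amplex Red, tested at 5 uM (on this read-out lower numbers stand for a stronger effect and higher numbers for a weaker effect at the one concentration tested), compound 1 stands lowest of the three numbers, with compound 3 nearest and compound 2 furthest, both beyond the scatter. The step to compound 4 (`O=C(c1ccccc1)c1ccc(NC(=S)Nc2ccc3[nH]ccc3c2)cc1`) is benzoyl in place of hydroxy on an aromatic carbon. Among the measured compounds shown here, two measured steps bear on it, since both also remove the hydroxy: a number 46.8 percentage points higher from compound 1 to compound 2 (beyond the scatter) and a number 24.8 percentage points higher from compound 1 to compound 3 (beyond the scatter). Benzoyl, like acetyl, brings a carbonyl, so the acetyl step is the closer guide, while the hydroxymethyl step marks the larger end. A rise beyond the scatter is therefore expected, of the size a number 28.5 percentage points higher from compound 1 to compound 4 (beyond the scatter). Compound 4 is estimated at 70%, with a range from 50% to 90%.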

Compound 4, a percentage reported as activity, at one concentration (the size of the read-out at that concentration, not a potency): 79.1%
The estimate for compound 4 lay 9.1 percentage points below the measured number, within the range that was stated.
By their numbers in this assay, from the lowest: compound 1; then compound 3; then compounds 4 and 2 (each within the scatter of the next).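

In this assay, benzoyl in place of hydroxy gives a number 37.6 percentage points higher from compound 1 to compound 4 (beyond the scatter) and so leaves compound 1 with the lowest number of the four, a third replacement of the hydroxy that does so. Phenyl in place of methyl on the carbonyl carbon gives a number 12.8 percentage points higher from compound 3 to compound 4 (beyond the scatter) and shows that the group on the carbonyl also counts, while benzoyl in place of hydroxymethyl gives a number 9.2 percentage points lower from compound 2 to compound 4 (within the scatter) and separates neither compound from the other. Nothing available accounts for these differences. As far as these compounds go, whether a methoxy group, an amine or a carboxylic acid at this position would match compound 1 remains open.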